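Working notes: from 4-nitrophenyl to 4-fluorophenyl

A few compounds are considered here, and "the series" means these few. Any claim that something is new, unique, unknown or untested is made for them only; others in the source may bear on it.

Measured so far in a functional assay on B16 cells (Mus musculus) for cytotoxicity, read by MTT assay, with a stated time of 72 h; a lower number here means a stronger inhibitor, a higher number a weaker inhibitor
compound 1 `COc1ccc(-c2cc(=O)c3c(O)cc(OCCCCN4CCN(C)CC4)c(OC)c3o2)cc1` gives 4100 nM
compound 2 `COc1c(OCCCCN2CCN(C)CC2)cc(O)c2c(=O)cc(-c3ccc(C)cc3)oc12` gives 5430 nM
compound 3 `COc1c(OCCCCN2CCN(C)CC2)cc(O)c2c(=O)cc(-c3ccc([N+](=O)[O-])cc3)oc12` gives 2890 nM

Compound 3 stands at 2890 nM in this assay and its steps to the other two compounds stay within the scatter, so no order among the three can be read from these numbers.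

The unmeasured compound 4 `COc1c(OCCCCN2CCN(C)CC2)cc(O)c2c(=O)cc(-c3ccc(F)cc3)oc12` differs from compound 3 by fluoro in place of nitro on an aromatic carbon para to a large group.

Measured exchanges at that carbon give a 1.3-fold higher number from compound 1 to compound 2 (0.12 log units; within the scatter) and a 1.4-fold lower number from compound 1 to compound 3 (0.15 log units; within the scatter) and a 1.9-fold lower number from compound 2 to compound 3 (0.27 log units; within the scatter) with all three within the scatter, so no step beyond the scatter is expected in this assay for this exchange. Fluoro itself has no measured example in the series.

The estimated change is a 1.3-fold higher number from compound 3 to compound 4 (0.12 log units; within the scatter) and it is expected to stay within the scatter, with no firm direction. For compound 4 the estimated value is 3800 nM with an expected range from 1900 nM to 7000 nM in these measurements.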

Compound 4, half-maximal inhibitory concentration: 4320 nM
Beside the measured number, compound 4's estimate is 1.1-fold (0.06 log units) below it; the range from low to high includes it.
By their numbers in this assay, from the lowest: compounds 3, 1, 4 and 2 (each within the scatter of the next).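

In this assay, fluoro now joins nitro, methyl and methoxy on the aromatic carbon para to a large group, and all three of its steps lie within the scatter (a 1.5-fold higher number from compound 3 to compound 4 (0.17 log units; within the scatter); a 1.3-fold lower number from compound 2 to compound 4 (0.10 log units; within the scatter); a 1.1-fold higher number from compound 1 to compound 4 (0.02 log units; within the scatter)). Exchanging nitro, with 3 heavy atoms and 2 hydrogen-bond acceptors, for fluoro, with 1 heavy atom and no hydrogen-bond acceptors, gives no step beyond the scatter, so the four compounds still show no order at this position. No evidence is available to explain these numbers.

As far as these compounds go, whether any group on this carbon can move the number beyond the scatter remains open; an amine or a carboxylic acid there would bear on that. All four compounds share the same chain and core, so they say nothing about a longer chain.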